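Aryl change on the shared core: compound 2 to compound 4

The source may hold more compounds than are shown below. What is called first, only, known or untested is meant among the compounds shown, and "the series" means these compounds.

Compound 2 `Cn1c(-c2ccc(O)cc2)nc2c(NC3CCCC3)ncnc21` stands highest of the two numbers in a functional assay on CHO cells for antagonist activity at adenosine receptor A2b (Homo sapiens), read by 33P incorporation, with a stated time of 20 min (on this read-out lower numbers stand for stronger inhibition and higher numbers for weaker inhibition), where compound 2 gives 17800 nM; the nearest, compound 3 `CCn1c(-c2ccccc2)nc2c(N)ncnc21`, gives 3020 nM. Compound 1 `Cn1c(-c2ccc(C(=O)O)cc2)nc2c(NC3CCCC3)ncnc21` returns only a limit in this assay, > 30000 nM. For the measured compounds named here, the single measured one-place step, an at least 1.6-fold lower number from compound 1 to compound 2 (0.22 log units; that floor lies within the scatter), rests on the limit of > 30000 nM in this assay, at which 1 of the 3 values shown sits, and so its size is only a floor. Compound 4 `Cc1ccccc1-c1nc2c(NC3CCCC3)ncnc2n1C` differs from compound 2 by 2-methylphenyl in place of 4-hydroxyphenyl on an aromatic carbon. That change again removes an oxygen-bearing substituent from the aryl ring, so the measured step bears on it in direction but not in size; compound 3, with a bare phenyl, differs from compound 2 in more than one place. For compound 4 a lower number is expected, estimated at 6000 nM (range 1500 nM to 25000 nM), a step of a 3.0-fold lower number from compound 2 to compound 4 (0.47 log units; beyond the scatter).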

Compound 4, inhibition constant: > 30000 nM
Compound 4 gave a limit, no number; the forecaster's own chance of this, stated with the estimate: 10%; at least 5.0-fold (0.69 log units) between middle value and limit.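

At the aromatic carbon between two ring nitrogen atoms, an aryl group without oxygen brings no lower number in this assay: 2-methylphenyl in place of 4-hydroxyphenyl gives an at least 1.6-fold higher number from compound 2 to compound 4 (0.22 log units; that floor lies within the scatter). Compound 4 is read only as a limit, so the step shows direction and a floor, not a size: the limit of > 30000 nM in this assay, at which 2 of the 4 values shown sit.

Still open, as far as these compounds go, is whether 4-methylphenyl, or a phenyl ring carrying an amine or a methoxy group, would give a number rather than a limit. That would separate the entering methyl from the leaving hydroxy.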